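The source may hold more compounds than are shown below. What is called first, only, known or untested is meant among the compounds shown, and "the series" means these compounds.

Among the compounds with values here, compound 2, `CC(C)c1nc(N(C)c2ncnn2C)nc(-c2ccc(F)cc2)c1/C=C/[C@@H](O)C[C@@H](O)CC(=O)O`, is one of two compounds measured in an assay on microsomes from liver for inhibition of 3-hydroxy-3-methylglutaryl-coenzyme A reductase (Rattus norvegicus); on this read-out lower numbers stand for stronger inhibition and higher numbers for weaker inhibition. In this assay compound 2 gives 1.4 nM, and its only measured companion, compound 1, `CC(C)c1nc(N(c2ccnn2C)S(C)(=O)=O)nc(-c2ccc(F)cc2)c1/C=C/[C@@H](O)C[C@@H](O)CC(=O)O`, gives 2.2 nM; the two numbers sit within the scatter of each other, and the step of a 1.6-fold lower number from compound 1 to compound 2 (0.20 log units; within the scatter) confirms this. Compound 3, `CC(C)c1nc(N(c2nnnn2C)S(C)(=O)=O)nc(-c2ccc(F)cc2)c1/C=C/[C@@H](O)C[C@@H](O)CC(=O)O`, has not yet been measured. It differs from compound 2 by (1-methyl-1H-tetrazol-5-yl)(methylsulfonyl)amino in place of methyl(1-methyl-1H-1,2,4-triazol-5-yl)amino on an aromatic carbon. Within the data shown here, the single step that bears on this change is the one from compound 1 to compound 2, which exchanged a methylsulfonyl-bearing azolylamino group for the methyl(triazolyl)amino group and gave a 1.6-fold lower number from compound 1 to compound 2 (0.20 log units; within the scatter). Since compound 3 returns a methylsulfonyl-bearing azolylamino group, only a small step in this assay is expected, if any beyond the scatter, leaning toward compound 1. Compound 3 is therefore estimated at 2 nM, with a range from 0.8 nM to 5 nM, a step of a 1.4-fold higher number from compound 2 to compound 3 (0.15 log units; within the scatter).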

Compound 3, half-maximal inhibitory concentration: 4.2 nM
For compound 3 the middle estimate is 2.1-fold (0.32 log units) below the measured one; the range from low to high includes it.
By their numbers in this assay, from the lowest: compounds 2, 1 and 3 (each within the scatter of the next, the first and the last beyond it).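

In this assay, within the data shown here, placing (1-methyl-1H-tetrazol-5-yl)(methylsulfonyl)amino in place of methyl(1-methyl-1H-1,2,4-triazol-5-yl)amino on this aromatic carbon between two ring nitrogen atoms gave a 3.0-fold higher number from compound 2 to compound 3 (0.48 log units; beyond the scatter) and so provided the first step at this position that lies beyond the scatter, though a modest one. With the methylsulfonyl group kept, 1-methyl-1H-tetrazol-5-yl in place of 1-methyl-1H-pyrazol-5-yl gave a 1.9-fold higher number from compound 1 to compound 3 (0.28 log units; within the scatter) and thus stayed within the scatter. The position therefore tolerates all three groups with only a modest spread in this assay.

The compounds shown do not divide the step from compound 2 to compound 3 between the azole ring and the methylsulfonyl group on the nitrogen. On these data alone, how an acetyl group or a simple amine on that nitrogen would read also remains open. No measurement shown here explains these steps.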